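A few compounds are considered here, and "the series" means these few. Any claim that something is new, unique, unknown or untested is made for them only; others in the source may bear on it.

Compound 3 `CN1CCCN(C(=S)[C@@H]2CCCN2C(=O)NCc2ccc(C(=O)N3CCCCc4sccc43)cc2Cl)CC1` belongs to a small set built on a shared core. In an assay on isolated protein with Oxytocin receptor (Homo sapiens) as the target (on this read-out lower numbers stand for an effect already at smaller amounts and higher numbers for an effect only at larger amounts of compound), compound 3 gives 810 nM. Its nearest neighbour is compound 1 `Cc1cc(C(=O)N2CCCCc3sccc32)ccc1CNC(=O)N1CCC[C@H]1C(=S)N1CCCN(C)CC1`, which in this assay gives 640 nM; the pair differ only by a 1.3-fold higher number from compound 1 to compound 3 (0.10 log units; within the scatter). The third measured member, compound 2 `CO[C@@H]1C[C@@H](C(=O)N2CCC(N3CCCCC3)CC2)N(C(=O)NCc2ccc(C(=O)N3CCCCc4sccc43)cc2Cl)C1`, gives 2200 nM in this assay; it differs from compound 3 in two places at once, so no single step can be read from it. Compound 4 `CO[C@@H]1C[C@@H](C(=S)N2CCCN(C)CC2)N(C(=O)NCc2ccc(C(=O)N3CCCCc4sccc43)cc2Cl)C1` is not yet measured. It differs from compound 3 by methoxy in place of hydrogen on a saturated ring carbon. Among the compounds with values here, none of the measured steps covers this change: the only single step known concerns the aromatic substituent, and that was within the scatter. Compound 2 carries the same methoxy group but also a different amide part, so it cannot be read as a guide. The step of a 1.2-fold higher number from compound 3 to compound 4 (0.09 log units; within the scatter) is therefore expected to stay within the scatter. Compound 4 is estimated at 1000 nM, between 400 nM and 2500 nM.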

Compound 4, half-maximal effective concentration: 430 nM
Compound 4: the middle estimate sits 2.3-fold (0.37 log units) above what was measured, within the range that was stated.
By their numbers in this assay, from the lowest: compounds 4, 1 and 3 (each within the scatter of the next); then compound 2.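

In this assay the methoxy on this saturated ring carbon, two ring bonds from the ring nitrogen, gives a 1.9-fold lower number from compound 3 to compound 4 (0.28 log units; within the scatter). Within the data shown here, the only earlier single step concerned chloro in place of methyl on an aromatic carbon, so this is the first reading of a change on the five-membered ring itself, and here too the two compounds cannot be told apart, which means this carbon carries a methoxy with no shift beyond the scatter. Nothing at hand gives a reason for this outcome.

As far as these compounds go, whether a hydroxyl, an ethoxy or an amine on the same carbon would also stay within the scatter remains open. From the compounds shown here alone, it is equally open whether methoxy gives so small a step alongside the amide part of compound 2.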